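This account rests on a few compounds, and the source may have more. Where it says the series, first, only, none or still open, it means among the compounds named here.

Measured so far: compound 1 `CCOC(=O)c1cnc(C)nc1NN1C(=O)C=C(C)C1=O` gives 16000 nM in a functional assay on Jurkat cells for inhibition of nuclear factor NF-kappa-B complex (Homo sapiens); a lower number here means a stronger inhibitor, a higher number a weaker inhibitor; compound 2 `CCOC(=O)c1cnc(C(=O)c2ccco2)nc1NN1C(=O)C=C(C)C1=O` gives 700 nM.

Among the compounds with values here, compound 2 holds the lower of the two numbers in this assay, with compound 1 as its only comparison. Compound 3 `CCOC(=O)c1cnc(Sc2ccccc2)nc1NN1C(=O)C=C(C)C1=O` differs from compound 2 by phenylsulfanyl in place of (furan-2-yl)carbonyl on an aromatic carbon, sitting between two ring nitrogen atoms. Within the data shown here, the one measured step that bears on this is a 23-fold lower number from compound 1 to compound 2 (1.36 log units; beyond the scatter), where a group carrying an aromatic ring in place of methyl gave a far lower number. Phenylsulfanyl also carries an aromatic ring, though not the same one, so a modest rise of a 2.9-fold higher number from compound 2 to compound 3 (0.46 log units; beyond the scatter) is expected. For compound 3 the estimate is 2000 nM, range 500 nM to 8000 nM.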

Compound 3, half-maximal inhibitory concentration: 1000 nM
Beside the measured number, compound 3's estimate is 2.0-fold (0.30 log units) above it; measured number inside the range.
By their numbers in this assay, from the lowest: compounds 2 and 3 (each within the scatter of the next); then compound 1.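

In this assay, the step of a 1.4-fold higher number from compound 2 to compound 3 (0.15 log units; within the scatter) shows that phenylsulfanyl and (furan-2-yl)carbonyl cannot be told apart at this position between two ring nitrogen atoms, so a carbonyl link and a furan are not required for a low number here. The gain over methyl also appears with a second, different group: a 16-fold lower number from compound 1 to compound 3 (1.20 log units; beyond the scatter). No measurement explains why these two groups match.

As far as these compounds go, it remains open whether an amine or a butyl chain at this position would give an equally low number, which would show whether an aromatic ring matters at all.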